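Hydroxy on the core aromatic ring of compound 2

The source may report more compounds than this note shows. Statements on the series, on what has been measured and on what is new or still open speak of the compounds shown alone.

The series is followed in a functional assay on MCF7 cells (Homo sapiens) for inhibition, in the presence of a further agent that is not named here; a higher number here means a weaker inhibitor, a lower number a stronger inhibitor. Compound 1 `Nc1ccc(-c2cc(=O)c3c(N)c(Cl)ccc3o2)cc1` gives only a limit, > 10000 nM, and no number. Compound 2 `Nc1ccc(-c2cc(=O)c3c(N)cccc3o2)cc1` gives 210 nM and compound 3 `Nc1ccc(-c2cc(=O)c3c(N)c(F)cc(F)c3o2)cc1` gives 46 nM. Of the two numbers shown, compound 2 sits highest, with compound 3 the nearest and lower; no single-place step links these two. For the measured compounds named here, the one measured step, an at least 47-fold lower number from compound 1 to compound 2 (1.67 log units; beyond the scatter), shows that a substituent on the core aromatic ring can move the read-out a long way. Compound 1 sits at the limit of > 10000 nM in this assay, at which 1 of the 3 values shown sits.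

Compound 4 `Nc1ccc(-c2cc(=O)c3c(N)ccc(O)c3o2)cc1` is not yet measured. It differs from compound 2 by hydroxy in place of hydrogen on an aromatic carbon. This change sits at a different place from the chloro removed in the step from compound 1 to compound 2, so that step bears on it only by showing how sensitive this ring is to substitution; compound 3 adds that two fluoro groups on the same ring go with a lower number than compound 2. Going by these compounds, the direction therefore stays open. For compound 4 in this assay a step of a 1.1-fold lower number from compound 2 to compound 4 (0.02 log units; within the scatter) is expected, small and within or near the scatter. Compound 4 is estimated at 200 nM, between 60 nM and 700 nM.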

Compound 4, half-maximal inhibitory concentration: 16000 nM
For compound 4 the middle estimate is 80-fold (1.90 log units) below the measured one, outside the stated range (above it).
By their numbers in this assay, from the lowest: compound 3; then compound 2; then compound 4.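

In this assay, for the compounds shown here, the hydroxy, para to an amino group on the core of compound 2, brings a 76-fold higher number from compound 2 to compound 4 (1.88 log units; beyond the scatter), a large step and the only measured single-place change at this position. With an at least 47-fold lower number from compound 1 to compound 2 (1.67 log units; beyond the scatter), a step read from a limit at a different place on the same ring, a single added group now goes with a weaker inhibitor at two places on this ring. Compound 3 goes against that pattern: with fluoro on the carbon that carries the hydroxy in compound 4 and a second fluoro elsewhere on the ring, compound 3 gives 46 nM, so a substituent on that carbon does not by itself rule out a low number, although compound 3 differs from compound 2 in two places.

Going by these compounds, whether the loss follows the hydroxy itself or any lone group on this carbon stays open, and a methoxy or a single fluoro there would separate the two. Nothing shown accounts for the size of this step.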